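The source may hold more compounds than are shown below. What is called first, only, known or untested is meant among the compounds shown, and "the series" means these compounds.

Compound 3 `CCC(CC)OC(=O)C1=C(C)NC(=O)NC1c1ccco1` gives 2% in an assay on membranes from CHO cells for displacement of a labelled ligand from adenosine receptor A1 (Homo sapiens), read by scintillation counting, with a stated time of 60 min, tested at 1 uM (a higher number here means more inhibition at the concentration tested (going by the name of the read-out), a lower number less inhibition), the lowest of the three numbers; compound 2 `CCSC(=O)C1=C(C)NC(=O)NC1c1ccsc1` gives 11%, which stays within the scatter of compound 3, while compound 1 `CC1=C(C(=O)OC(C)(C)C)C(c2ccsc2)NC(=O)N1` gives 15%, beyond the scatter. Within the data shown here, the only measured step, a number 4 percentage points lower from compound 1 to compound 2 (within the scatter), alters the group on the carbonyl carbon and does not bear on a change of the aromatic ring. Compound 4 `CCC(CC)OC(=O)C1=C(C)NC(=O)NC1c1ccsc1` differs from compound 3 by thiophen-3-yl in place of furan-2-yl on a saturated ring carbon. Among the measured compounds shown here, no measured pair isolates this change; compounds 1 and 2 carry thiophen-3-yl and compound 3 carries furan-2-yl, so a modest rise, still within the scatter, is expected, a number 6 percentage points higher from compound 3 to compound 4 (within the scatter). Compound 4 is estimated at 8%, with a range from 0% to 18%.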

Compound 4, a percentage reported as inhibition, at one concentration (the size of the read-out at that concentration, not a potency): 22%
The estimate for compound 4 lay 14 percentage points below the measured number; the whole stated range lies below it.
By their numbers in this assay, from the lowest: compounds 3, 2, 1 and 4 (each within the scatter of the next, the first and the last beyond it).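

Among these compounds, on the saturated ring carbon, thiophen-3-yl in place of furan-2-yl gives a number 20 percentage points higher from compound 3 to compound 4 (beyond the scatter) in this assay, the only pair that isolates this ring change, with the pentan-3-yl group on the oxygen held fixed. On the carbonyl carbon, (pentan-3-yl)oxy in place of ethylsulfanyl gives a number 11 percentage points higher from compound 2 to compound 4 (beyond the scatter) and pentan-3-yl in place of tert-butyl on the oxygen gives a number 7 percentage points higher from compound 1 to compound 4 (within the scatter), so that group also matters little beyond the thioester-to-ester step. Nothing available explains these steps.

Open: whether the thiophen-3-yl step holds with other groups on the carbonyl carbon. From the compounds shown here alone, also open: how a phenyl ring on the saturated ring carbon, or an amine on the carbonyl carbon, would read.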